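This account rests on a few compounds, and the source may have more. Where it says the series, first, only, none or still open, it means among the compounds named here.

Compound 1 `CCCCOC1(c2ccc(Br)cc2)SC=C(C)n2c1noc2=O` gives 78000 nM in a functional assay on A2780/DX3 cells (Homo sapiens) for antiproliferative activity, read by MTT assay, with a stated time of 3 days; on this read-out higher numbers stand for weaker inhibition and lower numbers for stronger inhibition. Compound 2 `COC1(c2ccc(Br)cc2)SC=C(C)n2c1noc2=O` reaches only the limit of this assay, > 100000 nM. The step of an at least 1.2-fold lower number from compound 2 to compound 1 (0.10 log units; that floor lies within the scatter) belongs to propyl in place of hydrogen on a saturated chain carbon bound to an oxygen on a saturated carbon. Compound 3 `CCCCCCCCCCCCCCCOC1(c2ccc(Cl)cc2)SC=C(C)n2c1noc2=O` also reaches only the limit of this assay, > 100000 nM. The difference between the core of compound 3 and that of compound 2 is not broken down here. Compound 4 `CCCCCCCCCCCCCCCCCCOC1(c2ccc(Cl)cc2)SC=C(C)n2c1noc2=O` has not been measured; it differs from compound 3 by propyl in place of hydrogen on a saturated chain carbon, ten or more bonds along the chain from an oxygen on a saturated carbon, the same group entering as from compound 2 to compound 1, but at a different place on the chain. Because compound 3 already sits at the limit of > 100000 nM in this assay, at which 2 of the 3 values shown sit, the step expected in this assay is a step that the limit leaves unreadable from compound 3 to compound 4. Compound 4 is estimated at 150000 nM in this assay.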

Compound 4, half-maximal inhibitory concentration: > 100000 nM
Compound 4 ended at the assay's limit (the forecaster's own chance of this, stated with the estimate: 80%); the middle value does not contradict the limit.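

Compound 3 and compound 4 both end at a limit, so no step can be read between them: the limit of > 100000 nM in this assay, at which 3 of the 4 values shown sit.

The compounds shown leave open how far the true values of compound 3 and compound 4 lie beyond that limit.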